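Swapping Ethynyl for Methyl on the Chain

The source may hold more compounds than are shown below. What is called first, only, known or untested is meant among the compounds shown, and "the series" means these compounds.

Measured in a functional assay on HCT-116 cells (Homo sapiens) for cytotoxicity, read by scintillation counting and thymidine incorporation, with a stated time of 72 h; on this read-out higher numbers stand for weaker inhibition and lower numbers for stronger inhibition:
- Compound 1 `CCOc1cc(C(=CC#N)c2cc(OC)cc(OC)c2)ccc1OC`: 34 nM
- Compound 2 `C#CC=C(c1cc(OC)cc(OC)c1)c1ccc(OC)c(OC)c1`: > 10000 nM

The value for compound 2 is a limit, not a number. Compound 2 thus sits at the limit of > 10000 nM in this assay, at which 1 of the 2 values shown sits, while compound 1 has a measured value. Compound 3 `CC=C(c1cc(OC)cc(OC)c1)c1ccc(OC)c(OC)c1` has not yet been measured. It carries methyl in place of ethynyl on a double-bonded chain carbon bound to a double-bonded chain carbon. Going by the values given here, no measured step shows what this swap does. In this assay, the expected at least 2.0-fold lower number from compound 2 to compound 3 (0.30 log units; that floor lies within the scatter) is therefore small, and towards stronger inhibition if it appears at all. The estimate for compound 3 is 5000 nM, with an expected range of 700 nM to 15000 nM.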

Compound 3, half-maximal inhibitory concentration: 480 nM
Estimate against measurement, compound 3: 10-fold (1.02 log units) above; measured number outside the range, below it.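

In this assay, methyl in place of ethynyl on a double-bonded chain carbon bound to a double-bonded chain carbon gives an at least 20-fold lower number from compound 2 to compound 3 (1.31 log units; beyond the scatter). This position is therefore sensitive to the group it carries, since one small uncharged group exchanged for another turns a limit into a measured value. The step has only a floor, as the value for compound 2 is a limit: the limit of > 10000 nM in this assay, at which 1 of the 3 values shown sits.

As far as these compounds go, whether the gain comes from losing ethynyl or from having methyl stays open. From the compounds shown here alone, how a longer chain such as propyl, or an amine, would behave here also stays open.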